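A Smaller Sulfur-Linked Heterocycle on a Shared Core

The source may hold more compounds than are shown below. What is called first, only, known or untested is meant among the compounds shown, and "the series" means these compounds.

Compound 1 `O=C(Nc1cc(Sc2ncnc3nc[nH]c23)c(O)c2ccccc12)c1ccc(Cl)cc1` carries a chloro-substituted benzamide on a shared core. In a functional assay on HCT-116 cells (Homo sapiens) for antiproliferative activity, read by MTT assay, with a stated time of 48 h (on this read-out higher numbers stand for weaker inhibition and lower numbers for stronger inhibition), compound 1 gives > 100000 nM, which is a limit of the assay rather than a number. Compound 3 `O=C(Nc1cc(Sc2ncnc3nc[nH]c23)c(O)c2ccccc12)c1ccc([N+](=O)[O-])cc1` differs from compound 1 by nitro in place of chloro on an aromatic carbon. In this assay compound 3 gives > 100000 nM, again a limit. The step that the two limits leave unreadable from compound 1 to compound 3 therefore cannot be read. Compound 2 `COc1ccc(/C=C/C(=O)Nc2cc(Sc3ncn[nH]3)c(O)c3ccccc23)cc1OC` is measured as well. In this assay compound 2 gives > 100000 nM, also a limit. Every measured value sits at the limit of > 100000 nM in this assay, at which 3 of the 3 values shown sit, so compound 1 stands level with the other two at the edge of what the assay can report.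

Compound 4 `O=C(Nc1cc(Sc2ncn[nH]2)c(O)c2ccccc12)c1ccc(Cl)cc1` arises from compound 1 by a group of 5 heavy atoms (2 carbon, 3 nitrogen; one five-membered aromatic ring with 3 hetero atoms) in place of a group of 9 heavy atoms (5 carbon, 4 nitrogen; one five-membered aromatic ring with 2 hetero atoms, one six-membered aromatic ring with 2 hetero atoms), on a sulfur. Within the data shown here, no measured step bears directly on this change, and the only measured step is unreadable. Compound 2 already carries the entering group and shows only a limit. Compound 4 is therefore expected to show no step beyond the scatter, a number no higher from compound 1 to compound 4 (the limit leaves the size open). The estimate for compound 4 is 100000 nM, within 30000 nM to 300000 nM, and most likely once more a limit.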

Compound 4, half-maximal inhibitory concentration: 43300 nM
For compound 4 the middle estimate is 2.3-fold (0.36 log units) above the measured one; the measured number falls inside the stated range.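

Among these compounds, replacing the larger two-ring group on the sulfur with 1H-1,2,4-triazol-5-yl gives, in this assay, an at least 2.3-fold lower number from compound 1 to compound 4 (0.36 log units; beyond the scatter), the first change in this set to yield a measured number rather than a limit. So what sits on this sulfur can shift the read-out on the shared core, although the true size of the step stays open, since it starts from a limit and only its minimum can be stated. Even so, this is one modest gain, and most of the set still rests at the edge of what the assay can report: the limit of > 100000 nM in this assay, at which 3 of the 4 values shown sit.

A single pair cannot separate the number of rings on the sulfur from the kind of ring atoms they contain. From the compounds shown here alone, how a plain phenyl ring or a methyl group on the sulfur would read remains open, as does the effect of nitro in place of chloro on compound 4.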